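Replacing the 2,4-dichlorophenyl Group of Compound 3

The source may hold more compounds than are shown below. What is called first, only, known or untested is meant among the compounds shown, and "the series" means these compounds.

In an ADME assay on NHDF cells (Homo sapiens) for cytotoxicity, read by MTT assay, with a stated time of 72 h (on this read-out higher numbers stand for weaker inhibition and lower numbers for stronger inhibition), compound 3 `COc1ccc(/C=C2\CCC/C(=C\c3ccc(Cl)cc3Cl)C2=O)cc1OC` gives > 50000 nM, which is a limit of the assay and not a number. The two other measured compounds give true numbers: compound 1 `COc1ccccc1/C=C1\CCC/C(=C\c2ccc(OC)c(OC)c2)C1=O` gives 18100 nM and compound 2 `COc1ccc(/C=C2\CCC/C(=C\c3ccc(O)cc3)C2=O)cc1OC` gives 26100 nM. The step between these two, a 1.4-fold higher number from compound 1 to compound 2 (0.16 log units; within the scatter), gives no ground for separating them.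

The unmeasured compound 4 `COc1cc(/C=C2\CCC/C(=C\c3ccc(OC)c(OC)c3)C2=O)ccc1O` differs from compound 3 as follows: 4-hydroxy-3-methoxyphenyl in place of 2,4-dichlorophenyl on a double-bonded chain carbon bound to a double-bonded ring carbon. Here, 4-hydroxy-3-methoxyphenyl takes the place of 2,4-dichlorophenyl on a double-bonded chain carbon bound to a double-bonded ring carbon.

Two measured steps change the same place and bear on this one. The first is an at least 2.7-fold higher number from compound 1 to compound 3 (0.44 log units; beyond the scatter), and the second is an at least 1.9-fold higher number from compound 2 to compound 3 (0.28 log units; that floor lies within the scatter). Both arrive at the 2,4-dichlorophenyl group, whereas the new step leaves it, so their direction is reversed here. Within the data shown here, only three compounds support this reading, and the second step alone would not settle it. A lower number, meaning stronger inhibition, is therefore expected, of about the size of the first step. The expected step is an at least 2.5-fold lower number from compound 3 to compound 4 (0.39 log units; beyond the scatter). For compound 4 the estimated value is 20000 nM, with an expected range from 9000 nM to 45000 nM.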

Compound 4, half-maximal inhibitory concentration: 13700 nM
Compound 4: the middle estimate sits 1.5-fold (0.16 log units) above what was measured; the measured number falls inside the stated range.
By their numbers in this assay, from the lowest: compounds 4, 1 and 2 (each within the scatter of the next). At a limit, above all of these: compound 3.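

In this assay, at this place on a double-bonded chain carbon bound to a double-bonded ring carbon, the change gives an at least 3.6-fold lower number from compound 3 to compound 4 (0.56 log units; beyond the scatter), so 4-hydroxy-3-methoxyphenyl now stands with 2-methoxyphenyl and 4-hydroxyphenyl as a third group that gives a true number. The size of that step is only a floor, since compound 3 stands at a limit of the assay and not at a number: the limit of > 50000 nM in this assay, at which 1 of the 4 values shown sits. Methoxy in place of hydrogen on an aromatic carbon gives a 1.9-fold lower number from compound 2 to compound 4 (0.28 log units; within the scatter), and 4-hydroxy-3-methoxyphenyl in place of 2-methoxyphenyl gives a 1.3-fold lower number from compound 1 to compound 4 (0.12 log units; within the scatter), so neither change separates these compounds, and among the four only the 2,4-dichlorophenyl group stands apart.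

The compounds shown leave open how far the true number of compound 3 lies past its limit, and whether both chlorines are needed for that result or a single one, as in 4-chlorophenyl, would give the same. They also leave open what happens at this place with a plain phenyl group, or with a ring carrying an amine or a carboxylic acid.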